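Swapping cyclohexyl for 4-methylphenyl on the ring nitrogen

This account rests on a few compounds, and the source may have more. Where it says the series, first, only, none or still open, it means among the compounds named here.

Measured compounds:
compound 1, `COc1ncc(-c2ccc3c(c2)N(c2ccc(C)cc2)C(=O)CO3)cc1NS(=O)(=O)c1ccc(F)cc1`: 15400 nM
compound 2, `COc1ncc(-c2ccc3c(c2)N(C2CCCCC2)C(=O)CO3)cc1NS(=O)(=O)c1ccc(F)cc1`: 30100 nM
compound 3, `O=C1COc2ccc(-c3cccc(NS(=O)(=O)c4ccc(F)cc4)c3)cc2N1C1CCCCC1`: 21400 nM

These values come from a functional assay on MCF7 cells (Homo sapiens) for antiproliferative activity, read by MTT assay, with a stated time of 72 h; a higher number here means a weaker inhibitor, a lower number a stronger inhibitor. Compound 1 and compound 2 share one core and differ in one place: 4-methylphenyl in place of cyclohexyl on an amide-type nitrogen in a ring That change gave a 2.0-fold lower number from compound 2 to compound 1 (0.29 log units; within the scatter). Compound 3 has a different core; how the two cores differ is not broken down here. Compound 4, `Cc1ccc(N2C(=O)COc3ccc(-c4cccc(NS(=O)(=O)c5ccc(F)cc5)c4)cc32)cc1`, is not yet measured and differs from compound 3 in the same way: 4-methylphenyl in place of cyclohexyl on an amide-type nitrogen in a ring The place is the same in both pairs, so this is the same change. Because the step of a 2.0-fold lower number from compound 2 to compound 1 (0.29 log units; within the scatter) stayed within the scatter, a step of similar size is expected here, a 1.9-fold lower number from compound 3 to compound 4 (0.29 log units; within the scatter), resting on compound 3 at 21400 nM. Compound 4 is therefore expected to show about 11000 nM in this assay, roughly between 5000 nM and 25000 nM.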

Compound 4, half-maximal inhibitory concentration: 32100 nM
Beside the measured number, compound 4's estimate is 2.9-fold (0.47 log units) below it, and the stated range ends below it.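

On the core of compound 3, in this assay, putting 4-methylphenyl in place of cyclohexyl gave a 1.5-fold higher number from compound 3 to compound 4 (0.18 log units; within the scatter), a step that alone stays within the noise of the measurement. Set against the earlier step, however, the same change does not behave alike on the two cores: the same change on two cores in this assay, a 2.0-fold lower number (0.29 log units; within the scatter) from compound 2 to compound 1 and a 1.5-fold higher number (0.18 log units; within the scatter) from compound 3 to compound 4, 2.9-fold (0.47 log units) apart, beyond the scatter of two such steps

So in this series the step seen on one core cannot be assumed to carry over unchanged to the other, although this rests on only two pairs and does not show why the cores differ. The compounds shown leave open how other groups on the amide-type nitrogen, such as benzyl or a longer chain ending in an amine, would behave on each core.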